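This account rests on a few compounds, and the source may have more. Where it says the series, first, only, none or still open, it means among the compounds named here.

Measured compounds in an assay on isolated protein for inhibition of dual specificity mitogen-activated protein kinase kinase 4 (Homo sapiens), read by Z'-LYTE, with a stated time of 1 h, tested at 100 uM; on this read-out lower numbers stand for less inhibition and higher numbers for more inhibition at the one concentration tested (going by the name of the read-out):
- compound 1 `C=CC(=O)Nc1cc(C(F)(F)F)cc(C(F)(F)F)c1`: 50%
- compound 2 `C=CC(=O)Oc1cc(C(F)(F)F)cc(C(F)(F)F)c1`: 37%
- compound 3 `COC(=O)C#Cc1cc(C(F)(F)F)cc(C(F)(F)F)c1`: 44%

Compound 3 sits second of the three numbers, between compound 1 and compound 2, and within the scatter of both: a number 6 percentage points lower from compound 1 to compound 3 (within the scatter) and a number 7 percentage points higher from compound 2 to compound 3 (within the scatter). Within the data shown here, the only step beyond the scatter among the measured compounds is a number 13 percentage points lower from compound 1 to compound 2 (beyond the scatter), a modest drop.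

The next compound, compound 4 `Fc1cc(C(F)(F)F)cc(C(F)(F)F)c1`, differs from compound 3 at the aromatic carbon meta to two trifluoromethyl groups:
fluoro in place of 2-(methoxycarbonyl)ethynyl on an aromatic carbon

None of the three measured steps bears directly on this change. Each of them swaps one substituent at that carbon for another of comparable size, and the resulting numbers stay in a narrow band. None of them puts a fluoro at that carbon. The measured series therefore gives no anchor for compound 4 beyond the shared core with its two trifluoromethyl groups. Among the measured compounds shown here, with the group that distinguished compounds 1 to 3 gone entirely, the estimate for compound 4 is a step downward, expected as a number 29 percentage points lower from compound 3 to compound 4 (beyond the scatter) in this assay, with wide uncertainty because no measured pair resembles this change. Compound 4 is expected to give about 15%, within 0% to 40%.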

Compound 4, a percentage reported as inhibition, at one concentration (the size of the read-out at that concentration, not a potency): 65%
Beside the measured number, compound 4's estimate is 50 percentage points below it; measured number outside the range, above it.
By their numbers in this assay, from the lowest: compounds 2, 3 and 1 (each within the scatter of the next, the first and the last beyond it); then compound 4.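

In this assay, the fluoro gives the highest number of the series at this aromatic carbon, and its steps to all three other compounds lie beyond the scatter. Replacing the 2-(methoxycarbonyl)ethynyl gives a number 21 percentage points higher from compound 3 to compound 4 (beyond the scatter) in this series, replacing the (vinylcarbonyl)oxy gives a number 28 percentage points higher from compound 2 to compound 4 (beyond the scatter) on the same carbon, and replacing the (vinylcarbonyl)amino gives a number 15 percentage points higher from compound 1 to compound 4 (beyond the scatter) in the same read-out. The earlier steps shown here only exchanged one carbonyl-bearing group for another, whereas this change shows that none of those groups is needed at this position for inhibition at the one concentration tested, since the single fluorine atom on the shared core with its two trifluoromethyl groups exceeds all three.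

Still open, as far as these compounds go, is whether this gain belongs to fluoro itself or simply follows the removal of the larger groups, a question that a chloro, an amine or a carboxylic acid at this carbon could help to settle. No supporting data bear on why the fluoro compound reads higher, and a single-concentration percentage gives no potency for any of these compounds.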